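Methyl to methoxy on the (3-methylphenyl)amino group

The source may hold more compounds than are shown below. What is called first, only, known or untested is meant among the compounds shown, and "the series" means these compounds.

Measured so far:
compound 1 `O=C(O)CCc1ccc(OCc2nnc(C(=O)Nc3ccccc3)s2)cc1` gives 1060 nM
compound 2 `Cc1cccc(NC(=O)c2nnc(COc3ccc(CCC(=O)O)cc3)s2)c1` gives 1770 nM

In a functional assay on CHO cells for agonist activity at Free fatty acid receptor 1 (Homo sapiens), read by calcium flux (a higher number here means that more compound is needed for the effect, a lower number that less compound is needed), compound 2 gives 1770 nM, the top of the two numbers, a placement that means little since a 1.7-fold higher number from compound 1 to compound 2 (0.22 log units; within the scatter). Compound 3 `COc1cccc(NC(=O)c2nnc(COc3ccc(CCC(=O)O)cc3)s2)c1` carries methoxy in place of methyl on an aromatic carbon, meta to a large group. Among the measured compounds shown here, no measured step exchanges methyl for methoxy; the only step seen, a 1.7-fold higher number from compound 1 to compound 2 (0.22 log units; within the scatter), lay within the scatter. Compound 3 is therefore expected to stay within the scatter of compound 2, a 1.2-fold lower number from compound 2 to compound 3 (0.07 log units; within the scatter). The estimate for compound 3 in this assay is 1500 nM, range 600 nM to 4000 nM.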

Compound 3, half-maximal effective concentration: 4680 nM
The estimate for compound 3 lay 3.1-fold (0.49 log units) below the measured number; measured number outside the range, above it.
By their numbers in this assay, from the lowest: compounds 1 and 2 (each within the scatter of the next); then compound 3.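

In this assay, this place on the aromatic ring, meta to a large group, proves sensitive to the choice of substituent: methoxy in place of methyl gives a 2.6-fold higher number from compound 2 to compound 3 (0.42 log units; beyond the scatter). Methoxy in place of hydrogen gives a 4.4-fold higher number from compound 1 to compound 3 (0.64 log units; beyond the scatter), whereas methyl in place of hydrogen gave only a 1.7-fold higher number from compound 1 to compound 2 (0.22 log units; within the scatter). No available evidence accounts for this difference between methyl and methoxy. Left open is whether ethyl, hydroxy or chloro at this place would stay with methyl or move with methoxy.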